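Fluoro for Hydrogen on Two Related Cores

The source may report more compounds than this note shows. Statements on the series, on what has been measured and on what is new or still open speak of the compounds shown alone.

Compound 1, `c1ccc(-[n+]2c[nH]c3ncncc32)cc1`, gives 0% in an assay on isolated protein for inhibition of Rho-associated protein kinase 1 (Homo sapiens), tested at 30 uM; on this read-out higher numbers stand for more inhibition at the one concentration tested (going by the name of the read-out) and lower numbers for less inhibition.
Compound 2, `Fc1ccc(-[n+]2c[nH]c3ncncc32)cc1`, gives 2% in this assay.
Compound 3, `CSc1ccc(-c2nc3c(Sc4ccccc4)ncnc3n2C)cc1`, gives 0% in this assay.

Among the measured compounds shown here, the single change fluoro in place of hydrogen on an aromatic carbon produced a number 2 percentage points higher from compound 1 to compound 2 (within the scatter). The difference between the core of compound 1 and the core of compound 3 is not broken down here; in this assay compound 3 sits level with compound 1, and both values lie within the scatter of compound 2.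

Compound 4, `CSc1ccc(-c2nc3c(Sc4ccc(F)cc4)ncnc3n2C)cc1`, differs from compound 3 by fluoro in place of hydrogen on an aromatic carbon. This is the same kind of change as that from compound 1 to compound 2, though the place differs in its surroundings: para to a group of 9 heavy atoms there, para to a large group here.

Compound 4 is expected to give a number 1 percentage points higher from compound 3 to compound 4 (within the scatter), because a number 2 percentage points higher from compound 1 to compound 2 (within the scatter) stayed within the scatter and compound 3 starts from 0%. Compound 4 is estimated at 1%, between -8% and 10%.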

Compound 4, a percentage reported as inhibition, at one concentration (the size of the read-out at that concentration, not a potency): 0%
Compound 4: middle estimate off by 1 percentage points, on the high side, and the stated range covers the measured number.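

Within this assay the swap of fluoro for hydrogen shows no change at the digits printed from compound 3 to compound 4 (within the scatter) and so leaves the number where it was on this core. Set beside the earlier step, the change reads alike on the two cores: the same change on two cores in this assay, a number 2 percentage points higher (within the scatter) from compound 1 to compound 2 and no change at the digits printed (within the scatter) from compound 3 to compound 4, 2 percentage points apart, within the scatter of two such steps

That agreement does not show that the change carries over in any useful sense, since all four numbers sit close to nothing and a step on a core with clear inhibition could look different.

Still open, as far as these compounds go, is whether another group in this place, such as an amine or a carboxylic acid, would move the number beyond the scatter. Also open, from the compounds shown here alone, is whether either core can show clear inhibition at all.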